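The source may hold more compounds than are shown below. What is called first, only, known or untested is meant among the compounds shown, and "the series" means these compounds.

Compound 1 `CO[C@H]1C[C@H](Oc2cc(F)c(F)c(-c3ccc4c(c3)CC[C@H]([C@@H]3C[C@H]3C(=O)O)O4)c2)C1` gives in a functional assay on HEK293 cells for agonist activity at Free fatty acid receptor 1 (Homo sapiens), read by HTRF and inositol phosphate accumulation, with a stated time of 60 min (a higher number here means that more compound is needed for the effect, a lower number that less compound is needed), a value of > 10000 nM, which is a limit of the assay rather than a number.
Compound 2 `COc1cc(O[C@H]2C[C@H](OC)C2)cc(-c2ccc3c(c2)CC[C@H]([C@@H]2C[C@H]2C(=O)O)O3)c1F` gives > 10000 nM in this assay, again a limit.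
Compound 3 `COc1cc(O[C@H]2C[C@H](OC)C2)cc(-c2ccc3c(c2)CC[C@H](CCc2nnn[nH]2)O3)c1F` gives > 10000 nM in this assay, also a limit.

Compound 3 thus stands at the limit with no number of its own, as do all values here, since (the limit of > 10000 nM in this assay, at which 3 of the 3 values shown sit). The measured steps a step that the two limits leave unreadable from compound 1 to compound 2 and a step that the two limits leave unreadable from compound 2 to compound 3 cannot be read for size. Compound 4 `CO[C@H]1C[C@H](Oc2cc(F)c(F)c(-c3ccc4c(c3)CC[C@H](CCc3nnn[nH]3)O4)c2)C1` differs from compound 3 by fluoro in place of methoxy on an aromatic carbon, the reverse of the change from compound 1 to compound 2, which itself stayed unreadable. No step beyond the scatter is therefore expected in this assay. Compound 4 is estimated at 20000 nM, with a range from 8000 nM to 100000 nM. The expected step is a step that the limit leaves unreadable from compound 3 to compound 4.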

Compound 4, half-maximal effective concentration: > 10000 nM
Compound 4: no number, only a limit; the forecaster's own chance of this, stated with the estimate: 85%; the middle value does not contradict the limit.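

No size can be read for the steps from compound 3 to compound 4 or from compound 1 to compound 4, since every compound sits at the same limit: the limit of > 10000 nM in this assay, at which 4 of the 4 values shown sit.

The compounds shown leave open how much either change matters, and what concentration, if any, gives a half-maximal effect.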